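A few compounds are considered here, and "the series" means these few. Any claim that something is new, unique, unknown or untested is made for them only; others in the source may bear on it.

Measured compounds:
- compound 1, `O=C(Nc1ccc(Oc2ccc(-c3nccs3)cc2)cc1)Nc1ccc(F)c(C(F)(F)F)c1`: 76.4%
- compound 2, `O=C(Nc1ccc(Oc2ccc(-c3nccs3)cc2)cc1)Nc1ccc(F)c(Cl)c1`: 37.3%

In a functional assay on A549 cells (Homo sapiens) for inhibition, read by MTT assay and WST assay, with a stated time of 72 h, tested at 10 uM (on this read-out lower numbers stand for less inhibition of growth and higher numbers for more inhibition of growth at the one concentration tested), compound 2 stands lowest of the two numbers, its nearest neighbour being compound 1, which is higher by a number 39.1 percentage points lower from compound 1 to compound 2 (beyond the scatter). Compound 3, `CC(=O)Oc1sccc1NC(=O)Nc1ccc(Oc2ccc(-c3nccs3)cc2)cc1`, differs from compound 2 by 2-acetoxythiophen-3-yl in place of 3-chloro-4-fluorophenyl on an amide-type nitrogen. No measured step covers this exchange; the only step shown, a number 39.1 percentage points lower from compound 1 to compound 2 (beyond the scatter), tells that changes on this aromatic ring can shift this assay strongly, without saying in which direction a wholly new ring would move it. Compound 3 is therefore expected near compound 2, at 35% with a range of 10% to 70%, a step of a number 2.3 percentage points lower from compound 2 to compound 3 (within the scatter) that is expected to stay within the scatter.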

Compound 3, percent growth inhibition at one concentration: 6.78%
Compound 3: middle estimate off by 28.2 percentage points, on the high side; measured number below the stated range.
By their numbers in this assay, from the lowest: compound 3; then compound 2; then compound 1.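

In this assay, exchanging the whole aromatic ring on the amide-type nitrogen, rather than one group on it, gives a number 30.5 percentage points lower from compound 2 to compound 3 (beyond the scatter). Measured against the trifluoromethyl-bearing ring, the same exchange gives a number 69.6 percentage points lower from compound 1 to compound 3 (beyond the scatter), so 2-acetoxythiophen-3-yl stands beyond the scatter under both phenyl groups shown at this position. Nothing available accounts for this drop.

The compounds shown leave open whether the drop goes with the thiophene ring or with the acetoxy group. A thiophen-3-yl carrying an amine or a carboxylic acid in place of acetoxy would bear on that question.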